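The compounds below may be only part of what the source reports. "The series", "measured", "known", "first", "only" and "open" are said of these compounds alone.

Measured compounds:
Compound 1 `COc1cc(C=C2C(=O)N(c3ccc(Cl)cc3)N(c3ccc(Cl)cc3)C2=O)ccc1O`: 22800 nM
Compound 2 `COc1cccc(C=C2C(=O)N(c3ccc(Cl)cc3)N(c3ccc(Cl)cc3)C2=O)c1`: 18100 nM
Compound 3 `CC(=C1C(=O)N(c2ccc(Cl)cc2)N(c2ccc(Cl)cc2)C1=O)c1ccc(O)cc1`: 76500 nM

These values come from a functional assay on MCF7 cells (Homo sapiens) for cytotoxicity, read by MTT assay, with a stated time of 72 h; a higher number here means a weaker inhibitor, a lower number a stronger inhibitor. There, compound 2 gives 18100 nM, which is within the scatter of compound 1, while compound 3 stands clearly higher at 76500 nM.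

Compound 4 `O=C1C(=Cc2ccco2)C(=O)N(c2ccc(Cl)cc2)N1c1ccc(Cl)cc1` keeps the shared core of compound 2 but carries furan-2-yl in place of 3-methoxyphenyl on a double-bonded chain carbon bound to a double-bonded ring carbon.

Within the data shown here, none of the measured compounds shows a replacement of this kind. The nearest evidence is a 1.3-fold lower number from compound 1 to compound 2 (0.10 log units; within the scatter), hydrogen in place of hydroxy on an aromatic carbon, and it bears on the new change only loosely. On that thin basis, no step beyond the scatter is expected in this assay, and no direction can be favoured. The expected change is a 1.1-fold higher number from compound 2 to compound 4 (0.04 log units; within the scatter).

For compound 4 the estimated value is 20000 nM, with an expected range from 8000 nM to 50000 nM.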

Compound 4, half-maximal inhibitory concentration: 20300 nM
For compound 4 the middle estimate is 1.0-fold (0.01 log units) below the measured one; low and high end bracket the measured number.
By their numbers in this assay, from the lowest: compounds 2, 4 and 1 (each within the scatter of the next); then compound 3.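

In this assay, furan-2-yl stands on the double-bonded chain carbon bound to a double-bonded ring carbon with a 1.1-fold higher number from compound 2 to compound 4 (0.05 log units; within the scatter), and in place of 4-hydroxy-3-methoxyphenyl with a 1.1-fold lower number from compound 1 to compound 4 (0.05 log units; within the scatter). Among these compounds, every earlier compound carries a six-membered aromatic ring of carbon only at this place, so compound 4 is the first to show that a five-membered aromatic ring with 1 hetero atom, at 5 heavy atoms rather than 8, reads within the scatter of those compounds. Nothing measured here accounts for this result.

From the compounds shown here alone, what remains open is whether a basic amine or a carboxylic acid carried on the furan-2-yl ring would stay within this range. Also open, going by these compounds, is how furan-2-yl would read with a methyl group on that same chain carbon, as compound 3 carries there.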